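The compounds below may be only part of what the source reports. "The series", "measured", "known", "first", "only" and "open" are said of these compounds alone.

Measured in a functional assay on B16-F10 cells (Mus musculus) for antiproliferative activity, read by MTT assay, with a stated time of 48 h; a higher number here means a weaker inhibitor, a lower number a stronger inhibitor:

- Compound 1 `COc1ccc(/C=C/c2cc(OC)cc(OC)c2/C=C/C(=O)c2cccc(OC)c2)cc1`: 4.3 ug/mL
- Compound 2 `COc1ccc(/C=C/c2cc(OC)cc(OC)c2/C=C/C(=O)c2ccc(C)cc2)cc1`: 5.3 ug/mL
- Compound 3 `COc1ccc(/C=C/c2cc(OC)cc(OC)c2/C=C/C(=O)c2cccc(Br)c2)cc1`: 5.1 ug/mL

These three compounds share a core and differ only in the group on the carbonyl carbon. Compound 3, at 5.1 ug/mL, cannot be separated from the other two. The number shows a 1.0-fold lower number from compound 2 to compound 3 (0.02 log units; within the scatter) and a 1.2-fold higher number from compound 1 to compound 3 (0.07 log units; within the scatter).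

Compound 4 `CCOc1ccc(C(=O)/C=C/c2c(/C=C/c3ccc(OC)cc3)cc(OC)cc2OC)cc1` has 4-ethoxyphenyl in place of 3-bromophenyl on a carbonyl carbon. For the measured compounds named here, no measured compound carries this group, so its effect has not been observed directly. The nearest evidence is the set of swaps at this same place. Besides the two steps above, the third shows a 1.2-fold higher number from compound 1 to compound 2 (0.09 log units; within the scatter). All three stay within the scatter, although they include changes of group and of its place on the ring.

On that basis, the expected result is a 1.1-fold lower number from compound 3 to compound 4 (0.03 log units; within the scatter), with no step beyond the scatter anticipated. For compound 4 the estimated value is 4.8 ug/mL, with an expected range from 2.6 ug/mL to 9 ug/mL.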

Compound 4, half-maximal inhibitory concentration: 6.4 ug/mL
For compound 4 the middle estimate is 1.3-fold (0.12 log units) below the measured one, within the range that was stated.
By their numbers in this assay, from the lowest: compounds 1, 3, 2 and 4 (each within the scatter of the next).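

In this assay the group on the carbonyl carbon now reaches 4-ethoxyphenyl, which has more heavy atoms than 3-bromophenyl and one hydrogen-bond acceptor against none, yet the swap gives a 1.3-fold higher number from compound 3 to compound 4 (0.10 log units; within the scatter) and so stays small. The same holds for ethoxy in place of methyl on an aromatic carbon, with a 1.2-fold higher number from compound 2 to compound 4 (0.08 log units; within the scatter) as its step, and for 4-ethoxyphenyl in place of 3-methoxyphenyl, with a 1.5-fold higher number from compound 1 to compound 4 (0.17 log units; within the scatter) as its step, so all four groups at this place remain indistinguishable. No evidence here bears on why these groups read alike.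

Every group shown is a phenyl ring carrying methoxy, methyl, bromo or ethoxy, so an amine, a carboxylic acid or a longer chain on that ring could still give a step beyond the scatter. As far as these compounds go, the shared core is the same in all four compounds, so how much it contributes to these numbers remains open.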